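The compounds below may be only part of what the source reports. "The series", "measured", "known", "first", "only" and "open" are said of these compounds alone.

Measured so far in an ADME assay on microsomes from liver (Homo sapiens) for metabolic stability, with a stated time of 10 min; on this read-out lower numbers stand for a less stable compound and higher numbers for a more stable compound:
- compound 1 `O=C(NS(=O)(=O)c1ccc(F)cc1)c1ccc(Nc2nc(NC3(c4ccc(Cl)cc4)CC3)nc(OCC(F)(F)F)n2)cc1`: 100%
- compound 2 `COC(=O)NCCS(=O)(=O)NC(=O)c1ccc(Nc2nc(NC3(c4ccc(Cl)cc4)CC3)nc(OCC(F)(F)F)n2)cc1`: 90%

Compound 1 stands at the top of the two numbers in this assay, but the step of a number 10 percentage points lower from compound 1 to compound 2 (within the scatter) is within the scatter, so the two compounds are not separated on this read-out.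

Compound 3 `CN(C)S(=O)(=O)NC(=O)c1ccc(Nc2nc(NC3(c4ccc(Cl)cc4)CC3)nc(OCC(F)(F)F)n2)cc1` is not yet measured. It differs from compound 1 in one place: dimethylamino in place of 4-fluorophenyl on a sulfonyl sulfur

Going by the values given here, one measured step bears on this change. From compound 1 to compound 2 the 4-fluorophenyl on the same sulfonyl sulfur was exchanged for an open-chain group, 2-((methoxycarbonyl)amino)ethyl, and the step of a number 10 percentage points lower from compound 1 to compound 2 (within the scatter) stayed within the scatter. The exchange for dimethylamino is of the same kind, a small open-chain group in place of the 4-fluorophenyl at the sulfonyl sulfur, and no step beyond the scatter is therefore expected in this assay for compound 3.

The expected step from compound 1 is a number 5 percentage points lower from compound 1 to compound 3 (within the scatter), which is within the scatter. For compound 3 the estimate in this assay is 95%, with a range from 80% to 100%.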

Compound 3, percent of the compound remaining: 86%
Beside the measured number, compound 3's estimate is 9 percentage points above it; the range from low to high includes it.
By their numbers in this assay, from the lowest: compounds 3, 2 and 1 (each within the scatter of the next, the first and the last beyond it).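

In this assay the sulfonyl sulfur now shows its first step beyond the scatter: dimethylamino in place of 4-fluorophenyl gives a number 14 percentage points lower from compound 1 to compound 3 (beyond the scatter) and so shows that an exchange at this position can register on this read-out, although only modestly. Dimethylamino in place of 2-((methoxycarbonyl)amino)ethyl on the same sulfur gives a number 4 percentage points lower from compound 2 to compound 3 (within the scatter) and leaves these two groups, neither of which carries a ring, unseparated, while compound 2 also remains unseparated from compound 1, so the three compounds do not fall into two clear groups. Nothing available explains the step from the 4-fluorophenyl to the dimethylamino compound.

Still open, on these data alone, is whether this step goes with the loss of the aromatic ring or with the entry of a nitrogen on the sulfonyl sulfur, a question that a plain ethyl chain, a piperidine ring or an unsubstituted phenyl at this place could help to settle. The compounds shown also leave open whether a primary amine or a carboxylic acid on this sulfur would stay within the scatter of compound 1 in this assay or fall further.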